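The source may report more compounds than this note shows. Statements on the series, on what has been measured and on what is new or still open speak of the compounds shown alone.

In a functional assay on MGC-803 cells (Homo sapiens) for inhibition, read by MTT assay, with a stated time of 48 h (a higher number here means a weaker inhibitor, a lower number a stronger inhibitor), compound 3, `Cc1ccc(NC(=O)NC(=O)c2ccc(OCc3ccc(C(F)(F)F)cc3)cc2)cc1-c1nc2ccccc2[nH]1`, gives the lowest of the two numbers, 14900 nM. Compound 2, `Cc1ccc(NC(=S)NC(=O)c2ccc(OCc3ccccc3Cl)cc2)cc1-c1nc2ccccc2[nH]1`, gives 45000 nM in this assay. Compound 1, `Cc1ccc(NC(=S)NC(=O)c2ccc(OCc3cccc(Cl)c3Cl)cc2)cc1-c1nc2ccccc2[nH]1`, reaches only a limit in this assay, > 100000 nM. Within the data shown here, the single measured step, an at least 2.2-fold lower number from compound 1 to compound 2 (0.34 log units; beyond the scatter), runs in the direction of a weaker inhibitor when the chloro is present. Compound 4, `Cc1ccc(NC(=O)NC(=O)c2ccc(OCc3cccc(Cl)c3Cl)cc2)cc1-c1nc2ccccc2[nH]1`, differs from compound 3 by 2,3-dichlorophenyl in place of 4-(trifluoromethyl)phenyl on a saturated chain carbon bound to an oxygen on an aromatic ring, bringing in the same dichlorophenyl that compound 1 carries. On that step a higher number is expected, since compound 1 sits at the limit of > 100000 nM in this assay, at which 1 of the 3 values shown sits, while compound 2 does not. Compound 4 is therefore estimated at 40000 nM, between 15000 nM and 150000 nM, an expected step of a 2.7-fold higher number from compound 3 to compound 4 (0.43 log units; beyond the scatter).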

Compound 4, half-maximal inhibitory concentration: > 100000 nM
Compound 4 ended at the assay's limit (the forecaster's own chance of this, stated with the estimate: 25%); at least 2.5-fold (0.39 log units) between middle value and limit.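

On the saturated chain carbon bound to an oxygen on an aromatic ring, 2,3-dichlorophenyl in place of 4-(trifluoromethyl)phenyl gives an at least 6.7-fold higher number from compound 3 to compound 4 (0.82 log units; beyond the scatter), so this group matters with the carbonyl compounds as well. Compound 1 with its thiocarbonyl and compound 4 with its carbonyl both carry 2,3-dichlorophenyl, and each value is a limit, not a number: the limit of > 100000 nM in this assay, at which 2 of the 4 values shown sit.

Between these two compounds, the carbonyl and thiocarbonyl difference cannot be read. Going by these compounds, it also stays open how a phenyl bearing an amine or a carboxylic acid at this position would behave in this assay.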